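Swapping hydroxyphenyl groups on a shared core

The source may hold more compounds than are shown below. What is called first, only, known or untested is meant among the compounds shown, and "the series" means these compounds.

Compound 1 `COc1cc(O)c(CC=C(C)C)c(O)c1C(=O)/C=C/c1cccc(O)c1`: 4800 nM
Compound 2 `COc1cc(O)c(CC=C(C)C)c(O)c1C(=O)/C=C/c1ccc(O)c(O)c1`: 2500 nM
Compound 3 `COc1cc(O)c(CC=C(C)C)c(O)c1C(=O)/C=C/c1cc(O)cc(O)c1`: 3200 nM

All three values come from a functional assay on HeLa cells (Homo sapiens) for cytotoxicity, read by MTT assay; on this read-out lower numbers stand for stronger inhibition and higher numbers for weaker inhibition. Compound 3 lies within the scatter of both other compounds, so the three cannot be ranked. Every measured step bearing on the next change is small: a 1.9-fold lower number from compound 1 to compound 2 (0.28 log units; within the scatter), a 1.5-fold lower number from compound 1 to compound 3 (0.18 log units; within the scatter) and a 1.3-fold higher number from compound 2 to compound 3 (0.11 log units; within the scatter), each within the scatter. Compound 4 `COc1cc(O)c(CC=C(C)C)c(O)c1C(=O)/C=C/c1ccccc1O` differs from compound 3 by 2-hydroxyphenyl in place of 3,5-dihydroxyphenyl on a double-bonded chain carbon bound to a double-bonded chain carbon. Within the data shown here, no measured compound carries 2-hydroxyphenyl, so the estimate is uncertain. The expected result is a 1.3-fold higher number from compound 3 to compound 4 (0.10 log units; within the scatter), which means no step beyond the scatter is expected. For compound 4 the estimated value is 4000 nM, with an expected range from 1800 nM to 9000 nM.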

Compound 4, half-maximal inhibitory concentration: 5900 nM
Estimate against measurement, compound 4: 1.5-fold (0.17 log units) below; low and high end bracket the measured number.
By their numbers in this assay, from the lowest: compounds 2, 3, 1 and 4 (each within the scatter of the next, the first and the last beyond it).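

Replacing 3,4-dihydroxyphenyl with 2-hydroxyphenyl gives the only step among these four compounds that clears the scatter, though a modest one (a 2.4-fold higher number from compound 2 to compound 4 (0.37 log units; beyond the scatter)). The other two changes at this position on the double-bonded chain carbon remain within the scatter (a 1.8-fold higher number from compound 3 to compound 4 (0.27 log units; within the scatter); a 1.2-fold higher number from compound 1 to compound 4 (0.09 log units; within the scatter)), so only the gap between compound 2 and compound 4 can be read as real. Nothing measured explains that gap.

The compounds shown leave open whether any hydroxy on this ring matters. A plain phenyl, or an amine or carboxylic acid on the ring in place of hydroxy, would help test this.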